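A few compounds are considered here, and "the series" means these few. Any claim that something is new, unique, unknown or untested is made for them only; others in the source may bear on it.

Compound 1 `Nc1nn(C(=O)Nc2ccc(Cc3ccccc3)cc2)c2ccccc12` and compound 2 `Nc1nn(C(=O)Nc2ccc(Cc3ccccc3)cc2)c2ccc(Cl)cc12` share a core and differ only on one aromatic carbon of the fused system. In a functional assay on LOX IMVI cells (Homo sapiens) for antiproliferative activity, read by sulforhodamine B assay, with a stated time of 48 h (a lower number here means a stronger inhibitor of growth, a higher number a weaker inhibitor of growth), compound 1 gives 477 nM, and compound 2 gives 50.3 nM. That single exchange, chloro in place of hydrogen on an aromatic carbon, produced a 9.5-fold lower number from compound 1 to compound 2 (0.98 log units; beyond the scatter). Within the data shown here, compound 2 therefore holds the lowest number of the two measured compounds, with compound 1 as its only neighbour at a higher number.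

Compound 3 `Nc1ccc2c(c1)c(N)nn2C(=O)Nc1ccc(Cc2ccccc2)cc1` differs from compound 2 by amino in place of chloro on an aromatic carbon. Among the measured compounds shown here, the one measured step bears on this only indirectly: it shows that the chloro carried by compound 2 matters at this position, but nothing shows what an amino group does there. With the chloro removed, part of the gain seen in compound 2 is expected to be lost, while the amino group might retain some of it. Compound 3 is expected to show a 4.0-fold higher number from compound 2 to compound 3 (0.60 log units; beyond the scatter) in this assay, with the estimate for compound 3 at 200 nM and a plausible range of 60 nM to 700 nM.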

Compound 3, concentration for 50% growth inhibition: 3380 nM
Beside the measured number, compound 3's estimate is 17-fold (1.23 log units) below it, outside the stated range (above it).
By their numbers in this assay, from the lowest: compound 2; then compound 1; then compound 3.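

On this aromatic carbon, the identity of the group decides the outcome in this assay, not merely whether a group is present: amino in place of chloro gives a 67-fold higher number from compound 2 to compound 3 (1.83 log units; beyond the scatter) and removes the whole gain that chloro had brought. Amino does more than fail to match chloro, since amino in place of hydrogen gives a 7.1-fold higher number from compound 1 to compound 3 (0.85 log units; beyond the scatter) and so moves the number in the opposite direction from the chloro exchange, leaving hydrogen between the two groups in this small set. Nothing measured alongside these growth-inhibition numbers accounts for the opposite effects of the two groups on the same carbon, so the result stands as an observation without an explanation.

The three compounds leave open whether the low number is particular to chloro or would also appear with fluoro, bromo or methyl on this carbon. They also leave open whether the loss seen with amino would persist with a hydroxyl, a methoxy or an acetamide in its place.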